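The source may hold more compounds than are shown below. What is called first, only, known or untested is meant among the compounds shown, and "the series" means these compounds.

Measured so far in a functional assay on A2780 cells (Homo sapiens) for antiproliferative activity, read by MTT assay, with a stated time of 48 h; a higher number here means a weaker inhibitor, a lower number a stronger inhibitor:
compound 1 `C=C(c1ccc2c(c1)C=CC(C)(C)O2)c1ccc(OC)cc1NC(=O)CNC` gives 320 nM;
compound 2 `C=C(c1cc(OC)c(OC)c(OC)c1)c1ccc(OC)cc1NC(=O)CNC` gives 140 nM;
compound 3 `C=C(c1ccc2c(c1)C=CC(C)(C)O2)c1ccc(OC)cc1NC(=O)CNCC` gives 1870 nM.

Compound 2 has the lowest of the three numbers; the difference between its core and the core of compound 1 is not broken down here, and the two values simply show compound 2 at the lower number. Compound 1 and compound 3 share a core and differ by methyl in place of hydrogen on a saturated chain carbon bound to an amine nitrogen, a change that gave a 5.8-fold higher number from compound 1 to compound 3 (0.77 log units; beyond the scatter).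

Compound 4 `C=C(c1cc(OC)c(OC)c(OC)c1)c1ccc(OC)cc1NC(=O)CNCC` has not yet been measured in this assay. It carries the core of compound 2 and differs from compound 2 by methyl in place of hydrogen on a saturated chain carbon bound to an amine nitrogen, the same change as from compound 1 to compound 3, made on the other core. Among the compounds with values here, only that one pair supports the expectation, so the size of the step is uncertain. Compound 4 is expected to give a 5.7-fold higher number from compound 2 to compound 4 (0.76 log units; beyond the scatter), resting on the step from compound 1 to compound 3. Compound 4 is therefore estimated at 800 nM, with a range of 350 nM to 1900 nM.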

Compound 4, half-maximal inhibitory concentration: 450 nM
Estimate against measurement, compound 4: 1.8-fold (0.25 log units) above; measured number inside the range.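

In this assay, methyl in place of hydrogen on a saturated chain carbon bound to an amine nitrogen, which turns methylamino into ethylamino, gave a 3.2-fold higher number from compound 2 to compound 4 (0.51 log units; beyond the scatter) and so raised the number on the core of compound 2, as it did on the core of compound 1. The change therefore carries from one core to the other in direction, and the two steps do not differ in size beyond the scatter: the same change on two cores in this assay, a 5.8-fold higher number (0.77 log units; beyond the scatter) from compound 1 to compound 3 and a 3.2-fold higher number (0.51 log units; beyond the scatter) from compound 2 to compound 4, 1.8-fold (0.26 log units) apart, within the scatter of two such steps. Within the data shown here, this rests on only two pairs, so it does not show that the step would hold on any further core, nor does it explain why the ethylamino compounds give the higher numbers.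

The compounds shown leave open how the series reads on either core with a primary amine, a dimethylamino group, or a longer or branched chain such as propylamino or isopropylamino. They also leave open whether the rise seen from methylamino to ethylamino continues with chain length.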